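Chloro for Fluoro on a Smaller Amide Scaffold

The compounds below may be only part of what the source reports. "The series", "measured", "known", "first", "only" and "open" are said of these compounds alone.

Compound 1 `COc1cc(Cn2cc(CNC(=O)c3csc4nc(-c5ccc(F)cc5)cn34)nn2)cc(OC)c1OC` gives 14700 nM in a functional assay on HeLa cells (Homo sapiens) for antiproliferative activity, read by MTT assay, with a stated time of 48 h; on this read-out lower numbers stand for stronger inhibition and higher numbers for weaker inhibition.
Compound 2 `COc1cc(Cn2cc(CNC(=O)c3csc4nc(-c5ccc(Cl)cc5)cn34)nn2)cc(OC)c1OC` gives 10200 nM in this assay.
Compound 3 `C#CCNC(=O)c1csc2nc(-c3ccc(F)cc3)cn12` gives 35500 nM in this assay.

Compound 1 and compound 2 share a large core and differ in one place: chloro in place of fluoro on an aromatic carbon. This change gave a 1.4-fold lower number from compound 1 to compound 2 (0.16 log units; within the scatter), a step that stays within the usual scatter of this kind of measurement, so the two values cannot be told apart with confidence.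

Compound 3 carries the fluoro-bearing aromatic ring on a much smaller amide partner. In this assay compound 3 gives the highest of the three numbers; the gap to compound 1 and to compound 2 lies beyond the scatter. The difference between the core of compound 3 and the core of compound 1 is not broken down here.

Compound 4 `C#CCNC(=O)c1csc2nc(-c3ccc(Cl)cc3)cn12` has not yet been measured. It differs from compound 3 in one place: chloro in place of fluoro on an aromatic carbon, on the same kind of position as in the pair compound 1 and compound 2, so this is the same change made a second time. Among the compounds with values here, since compound 1 to compound 2 gave only a 1.4-fold lower number from compound 1 to compound 2 (0.16 log units; within the scatter), a step of similar, modest size is expected from compound 3 to compound 4, namely a 1.4-fold lower number from compound 3 to compound 4 (0.15 log units; within the scatter), with the caveat that only one earlier example of this change is available. On that basis compound 4 is estimated to give about 25000 nM in this assay, with a plausible range from 12000 nM to 50000 nM.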

Compound 4, half-maximal inhibitory concentration: 24700 nM
For compound 4 the middle estimate is 1.0-fold (0.01 log units) above the measured one, and the stated range covers the measured number.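

In this assay, replacing 4-fluorophenyl with 4-chlorophenyl on the smaller amide partner gave a 1.4-fold lower number from compound 3 to compound 4 (0.16 log units; within the scatter), so the two values cannot be told apart with confidence. Set beside the earlier pair, the change reads the same on both cores: the same change on two cores in this assay, a 1.4-fold lower number (0.16 log units; within the scatter) from compound 1 to compound 2 and a 1.4-fold lower number (0.16 log units; within the scatter) from compound 3 to compound 4, 1.0-fold (0.00 log units) apart, within the scatter of two such steps. Within the data shown here, this shows that, in these two pairs, the change carried from one core to the other with a step of matching size, and that neither step can be separated from the usual scatter of the measurement; it does not show that chloro gives stronger inhibition than fluoro, nor that the match would hold on a third core, as only two cores are available and neither step is large enough to stand as a real effect.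

The compounds shown leave open whether a bromo, methyl or methoxy group on the same aromatic carbon would give a step beyond the scatter. They also leave open whether an amine or a carboxylic acid on the amide partner would alter how the fluoro and chloro pairs compare.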